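The compounds below may be only part of what the source reports. "The series", "measured", "known", "first", "only" and "open" are said of these compounds alone.

Compound 2 `Cc1cc(C)cc(NC(=O)COc2cc(C)nc3ccccc23)c1` gives 5.39 in a physicochemical assay for lipophilicity, read by HPLC, in phosphate buffer, measured as chromatographic lipophilicity, at pH 7.4 (a lower number here means a more polar compound, a higher number a more lipophilic compound), the lowest of the three numbers in hand. Compound 1 `COc1ccc2nc(C)cc(OCC(=O)Nc3cc(C)cc(C)c3)c2c1` gives 5.64 there, and a number 0.25 log units lower from compound 1 to compound 2 (within the scatter). Compound 3 `CSc1ccc2nc(C)cc(OCC(=O)Nc3cc(C)cc(C)c3)c2c1` gives 6.42; a number 1.03 log units higher from compound 2 to compound 3 (beyond the scatter), and a number 0.78 log units higher from compound 1 to compound 3 (beyond the scatter).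

Compound 4 `COc1ccc2c(OCC(=O)Nc3cc(C)cc(C)c3)cc(C)nc2c1` has not been measured. It differs from compound 2 by methoxy in place of hydrogen on an aromatic carbon. Among the compounds with values here, the one measured step that speaks to this change is the step from compound 1 to compound 2, where a hydrogen stands in place of a methoxy and the number moved only within the scatter. The methoxy of compound 4 sits on a different aromatic carbon of the shared core than that of compound 1, so the comparison is not exact, but a methoxy entering in place of hydrogen is nonetheless expected to move the number little, if at all. The step from compound 2 to compound 4 is therefore estimated as a number 0.21 log units higher from compound 2 to compound 4 (within the scatter), within the scatter or barely beyond it. For compound 4, a value of 5.6 is expected in this assay, with a range from 5.25 to 5.95.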

Compound 4, distribution coefficient: 5.59
Compound 4: the middle estimate sits 0.01 log units above what was measured, within the range that was stated.
By their numbers in this assay, from the lowest: compounds 2, 4 and 1 (each within the scatter of the next); then compound 3.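

Methoxy in place of hydrogen on this aromatic carbon, meta to a fused ring and para to a fused ring, gives a number 0.20 log units higher from compound 2 to compound 4 (within the scatter) in this assay, so this change does not separate the two compounds. The earlier step, a number 0.25 log units lower from compound 1 to compound 2 (within the scatter), concerned a methoxy on a different aromatic carbon of the shared core and also lies within the scatter, so the same reading now holds at two carbons. Compound 1 at 5.64 and compound 4 at 5.59 stand within the scatter of each other, so these two placements of methoxy are not told apart here.

Going by these compounds, whether an amine, a carboxylic acid or the methylsulfanyl that gave a number 0.78 log units higher from compound 1 to compound 3 (beyond the scatter) on the other carbon would move the number beyond the scatter on this carbon stays open. Nothing measured in the compounds shown offers a reason for any of these steps.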